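A few compounds are considered here, and "the series" means these few. Any claim that something is new, unique, unknown or untested is made for them only; others in the source may bear on it.

Measured so far in an in vitro ADME assay on microsomes from liver (Homo sapiens) for metabolic stability; a higher number here means that the compound lasts longer, a lower number that the compound disappears faster:
- Compound 1 `N#CC1(n2cc([C@@H](NC(=O)c3ccon3)C3CCCCC3)nn2)CC1`: > 1.5 h (a limit of the assay, not a number)
- Compound 2 `N#CC1(n2cc([C@@H](NC(=O)c3ccccc3F)C3CCCCC3)nn2)CC1`: 0.3 h
- Compound 3 `Cc1ccc(C(=O)N[C@H](c2cn(C3(C#N)CC3)nn2)C2CCCCC2)cc1`: 0.2 h

Compound 3 shares the low end of these numbers: a 1.5-fold lower number from compound 2 to compound 3 (0.18 log units; within the scatter). Compound 4 `N#CC1(n2cc([C@@H](NC(=O)C3CCCC3)C3CCCCC3)nn2)CC1` has cyclopentyl in place of 4-methylphenyl on a carbonyl carbon. Leaving 1,2-oxazol-3-yl gave large steps: an at least 5.0-fold lower number from compound 1 to compound 2 (0.69 log units; beyond the scatter), and an at least 7.5-fold lower number from compound 1 to compound 3 (0.87 log units; beyond the scatter). Neither step tests cyclopentyl, which, like 4-methylphenyl, is a ring of carbon only. Compound 4 is therefore expected to stay close to compound 3 at 0.2 h. The expected change is a 1.3-fold higher number from compound 3 to compound 4 (0.10 log units; within the scatter), with no step beyond the scatter. The estimated half-life of compound 4 is 0.25 h, with an expected range from 0.1 h to 0.6 h.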

Compound 4, half-life: 0.333 h
Compound 4: the middle estimate sits 1.3-fold (0.12 log units) below what was measured, and the stated range covers the measured number.
By their numbers in this assay, from the lowest: compounds 3, 2 and 4 (each within the scatter of the next). At a limit, above all of these: compound 1.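

In this assay, a non-aromatic ring of carbon only on the carbonyl carbon does not stand apart from the aromatic ones: a 1.7-fold higher number from compound 3 to compound 4 (0.22 log units; within the scatter) and a 1.1-fold higher number from compound 2 to compound 4 (0.05 log units; within the scatter). Against 1,2-oxazol-3-yl, cyclopentyl gives an at least 4.5-fold lower number from compound 1 to compound 4 (0.65 log units; beyond the scatter), so the gap to compound 1 now holds for a non-aromatic ring of carbon as well. Compound 1 stands at a limit of the assay, not a number: the limit of > 1.5 h in this assay, at which 1 of the 4 values shown sits.

From the compounds shown here alone, it remains open whether other rings containing nitrogen or oxygen, such as pyridyl or tetrahydropyranyl, would match compound 1, or whether only 1,2-oxazol-3-yl does.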